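Working notes: from compound 3 to compound 4

The source may hold more compounds than are shown below. What is called first, only, known or untested is meant among the compounds shown, and "the series" means these compounds.

Measured so far in a functional assay on PC-3 cells (Homo sapiens) for antiproliferative activity, read by MTT assay, with a stated time of 72 h (on this read-out lower numbers stand for stronger inhibition and higher numbers for weaker inhibition), for each compound:
- compound 1 `CCNC(=S)SCC1=CCOC1=O` gives 30600 nM
- compound 2 `O=C1OCC=C1CSC(=S)NC1CC1` gives 117000 nM
- compound 3 `CN(C)C(=S)SCC1=CCOC1=O` gives 147000 nM

Not yet measured: compound 4 `CC(C)NC(=S)SCC1=CCOC1=O`

Compound 3 cannot be told apart from compound 2 on these numbers, since the data show a 1.3-fold higher number from compound 2 to compound 3 (0.10 log units; within the scatter) as the gap between them. Compound 1 stands clear of both, with a 4.8-fold higher number from compound 1 to compound 3 (0.68 log units; beyond the scatter) on one side and a 3.8-fold higher number from compound 1 to compound 2 (0.58 log units; beyond the scatter) on the other.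

Compound 4 carries isopropylamino in place of dimethylamino on a thiocarbonyl carbon and so joins compound 1 and compound 2 in having a monosubstituted amino group. For the measured compounds named here, the closest precedent is ethylamino in compound 1, where the change to dimethylamino gave a 4.8-fold higher number from compound 1 to compound 3 (0.68 log units; beyond the scatter) and suggests that leaving dimethylamino may lower the number. Compound 2 goes against any simple rule for monosubstituted amino groups, given a 3.8-fold higher number from compound 1 to compound 2 (0.58 log units; beyond the scatter) on moving from ethylamino to cyclopropylamino.

In this assay a modest drop is therefore expected, and the estimated step is a 2.3-fold lower number from compound 3 to compound 4 (0.35 log units; beyond the scatter) in all. The estimate for compound 4 is 65000 nM with 28000 nM as the lower end and 140000 nM as the upper end of the expected range.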

Compound 4, half-maximal inhibitory concentration: 49400 nM
For compound 4 the middle estimate is 1.3-fold (0.12 log units) above the measured one; the measured number falls inside the stated range.
By their numbers in this assay, from the lowest: compounds 1 and 4 (each within the scatter of the next); then compounds 2 and 3 (each within the scatter of the next).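

In this assay, isopropylamino in place of dimethylamino on a thiocarbonyl carbon gives a 3.0-fold lower number from compound 3 to compound 4 (0.47 log units; beyond the scatter), which makes a second pair in which a monosubstituted amino group carries a lower number than dimethylamino, the first being ethylamino in compound 1. Methyl in place of hydrogen on the saturated chain carbon bound to the amide-type nitrogen leaves a 1.6-fold higher number from compound 1 to compound 4 (0.21 log units; within the scatter), so ethylamino and isopropylamino cannot be told apart on these numbers. Compound 2 remains the exception to any rule for monosubstituted amino groups: it cannot be told apart from the dimethylamino compound 3, and isopropyl in place of cyclopropyl on the amide-type nitrogen gives a 2.4-fold lower number from compound 2 to compound 4 (0.37 log units; beyond the scatter), so the group on the nitrogen matters as well as the hydrogen left on it.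

No measurement at hand bears on the reason for these differences. From the compounds shown here alone, it remains open whether a longer chain such as n-butylamino, or a benzylamino group, on the thiocarbonyl carbon would stay with compound 1 and compound 4 or fall with compound 2 and compound 3.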